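The source may report more compounds than this note shows. Statements on the series, on what has been measured and on what is new or still open speak of the compounds shown alone.

Working notes on the series, read in a functional assay on U-251 cells (Homo sapiens) for antiproliferative activity, read by MTT assay, with a stated time of 24 h; on this read-out higher numbers stand for weaker inhibition and lower numbers for stronger inhibition. Compound 1 (`COc1cc(OC)c(-c2coc3cc(OCC=C(C)C)ccc3c2=O)cc1OC`) gives 3500 nM, compound 2 (`C=CCOc1ccc2c(=O)c(-c3cc(OC)c(OC)cc3OC)coc2c1`) gives 5900 nM and compound 3 (`C#CCOc1ccc2c(=O)c(-c3cc(OC)c(OC)cc3OC)coc2c1`) gives 6450 nM. Compound 3 therefore cannot be separated from either of the others: a 1.1-fold higher number from compound 2 to compound 3 (0.04 log units; within the scatter) and a 1.8-fold higher number from compound 1 to compound 3 (0.27 log units; within the scatter).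

Compound 4 (`COc1cc(OC)c(-c2coc3cc(OCc4ccccc4)ccc3c2=O)cc1OC`) is the next case, with phenyl in place of ethynyl on a saturated chain carbon bound to an oxygen on an aromatic ring, so propargyloxy becomes benzyloxy: phenyl in place of ethynyl on a saturated chain carbon bound to an oxygen on an aromatic ring.

Among the compounds with values here, the steps that bear on this change are the exchanges at the same place, namely those two and a 1.7-fold higher number from compound 1 to compound 2 (0.23 log units; within the scatter). None of them brings in a ring, so the measured compounds only partly cover this change. With all three steps inside the scatter, no step beyond the scatter is expected in this assay, and no direction is favoured.

The estimated step is a 1.3-fold lower number from compound 3 to compound 4 (0.11 log units; within the scatter). Compound 4 is expected at 5000 nM, with an estimated range of 2200 nM to 11000 nM.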

Compound 4, half-maximal inhibitory concentration: 6750 nM
Estimate against measurement, compound 4: 1.4-fold (0.13 log units) below; the range from low to high includes it.
By their numbers in this assay, from the lowest: compounds 1, 2, 3 and 4 (each within the scatter of the next).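

Bringing a ring to this place, on a saturated chain carbon bound to an oxygen on an aromatic ring, gives no step beyond the scatter in this assay (a 1.0-fold higher number from compound 3 to compound 4 (0.02 log units; within the scatter)) (a 1.1-fold higher number from compound 2 to compound 4 (0.06 log units; within the scatter)) (a 1.9-fold higher number from compound 1 to compound 4 (0.29 log units; within the scatter)). The earlier steps shown here covered only open chains, so the flat reading now extends from ethynyl, vinyl and 2-methylprop-1-en-1-yl to phenyl, with its one six-membered aromatic ring of carbon only. No measured evidence bears on why these steps stay so small.

Still open, on these data alone, is whether an amine, a carboxylic acid or a longer chain at this same place would give a step beyond the scatter. As far as these compounds go, the shared core is the same in all four compounds, so the effect of changes there also remains open.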